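This account rests on a few compounds, and the source may have more. Where it says the series, first, only, none or still open, it means among the compounds named here.

The series rests on a shared core carrying two fluorinated benzylidene arms, and its members were tested in a functional assay on HepG2 cells (Homo sapiens) for cytotoxicity, read by MTT assay, with a stated time of 24 h; on this read-out lower numbers stand for stronger inhibition and higher numbers for weaker inhibition. Compound 1, `N#Cc1ccc(S(=O)(=O)N2C/C(=C\c3ccccc3F)C(=O)/C(=C/c3ccccc3F)C2)cc1`, gives 16500 nM in this assay. Compound 2, `Cc1ccc(S(=O)(=O)N2C/C(=C\c3ccc(F)cc3)C(=O)/C(=C/c3ccc(F)cc3)C2)cc1`, gives 4500 nM in this assay, the lower of the two numbers shown, and its gap to compound 1 lies beyond the scatter of repeated measurements. Compound 3, `CC(=O)Nc1ccc(S(=O)(=O)N2C/C(=C\c3ccc(F)cc3)C(=O)/C(=C/c3ccc(F)cc3)C2)cc1`, has not yet been measured. The change from compound 2 to compound 3 is acetamido in place of methyl on an aromatic carbon. Within the data shown here, no measured pair shows this change, so the size of its effect is not known from the data. Compound 3 is expected to stay close to compound 2, with a step of a 1.3-fold higher number from compound 2 to compound 3 (0.12 log units; within the scatter), within or barely beyond the scatter. Compound 3 is therefore estimated at 6000 nM, in a range from 2500 nM to 15000 nM.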

Compound 3, half-maximal inhibitory concentration: 7400 nM
Beside the measured number, compound 3's estimate is 1.2-fold (0.09 log units) below it, within the range that was stated.
By their numbers in this assay, from the lowest: compounds 2 and 3 (each within the scatter of the next); then compound 1.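

In this assay, among these compounds, acetamido in place of methyl on an aromatic carbon, para to a large group, gives a 1.6-fold higher number from compound 2 to compound 3 (0.22 log units; within the scatter), the first step that can be read at a single position. Compound 1 and compound 2 differ in more than one place, so they showed nothing about this position alone, whereas this pair shows that the larger acetamido, with its hydrogen-bond donor and acceptor, can stand here without a shift beyond the scatter. Nothing measured here gives a reason for this result.

Going by these compounds, whether an amine, a carboxylic acid or a longer chain at this same position would also stay within the scatter remains open. On these data alone, it is also open whether acetamido would give a similar step on the fluorinated benzylidene arms of compound 1.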